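Ring-closed amide at the meta position of the benzoic acid

A few compounds are considered here, and "the series" means these few. Any claim that something is new, unique, unknown or untested is made for them only; others in the source may bear on it.

Three compounds of this series have numbers in an assay on CHO cells for displacement of a labelled ligand from prostaglandin E2 receptor EP1 subtype (Homo sapiens); a higher number here means a weaker inhibitor, a lower number a stronger inhibitor. Compound 1 `CC(=O)Nc1cc(C(=O)O)cc(-n2c(C)ccc2-c2cc(Br)ccc2OCc2ccc(F)cc2F)c1` gives 0.398 nM and stands lowest of the three. Compound 2 `Cc1ccc(-c2cc(Cl)ccc2OCc2ccc(F)cc2F)n1-c1cc(C(=O)O)ccc1F` gives 6.31 nM, and compound 3 `Cc1ccc(-c2cc(Br)ccc2OCc2ccc(F)cc2)n1-c1cc(C(=O)O)ccc1F` gives 6.31 nM; both lie well beyond the scatter from compound 1, so compound 1 is the strongest inhibitor among the measured set. Compound 2 and compound 3 differ from compound 1 in several places at once, so no single step can be read from them.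

For the measured compounds named here, compound 4 `Cc1ccc(-c2cc(Br)ccc2OCc2ccc(F)cc2F)n1-c1cc(C(=O)O)cc(N2CCCC2=O)c1` keeps the shared core of compound 1 and changes only one group: 2-oxopyrrolidin-1-yl in place of acetamido on an aromatic carbon This removes the single hydrogen-bond donor while keeping one acceptor and adding two heavy atoms in a five-membered non-aromatic ring. Going by the values given here, no measured pair isolates this change, so the step is expected from compound 1 alone. A small loss, near the edge of the scatter, is expected for a 2.0-fold higher number from compound 1 to compound 4 (0.30 log units; within the scatter). Compound 4 is therefore estimated at 0.8 nM, within a range of 0.25 nM to 3 nM in this assay.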

Compound 4, half-maximal inhibitory concentration: 2 nM
Compound 4: the middle estimate sits 2.5-fold (0.40 log units) below what was measured; measured number inside the range.
By their numbers in this assay, from the lowest: compound 1; then compound 4; then compounds 2 and 3 (each within the scatter of the next).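

In this assay, the replacement of acetamido by 2-oxopyrrolidin-1-yl gives a 5.0-fold higher number from compound 1 to compound 4 (0.70 log units; beyond the scatter), the first single-place step read at this position, and it shows that the two groups are not interchangeable here. The size of the step is modest, and compound 4 keeps a low number at 2 nM. This one step combines loss of the hydrogen-bond donor with gain of a five-membered non-aromatic ring, and nothing at hand explains the loss or separates these two parts.

Still open, on these data alone, is how acetamido carrying a methyl group on the amide nitrogen would compare, as it would lack the amide hydrogen without the ring. Also open, as far as these compounds go, is how a plain amine or a longer acyl chain such as propionamido would read at this position.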